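The source may hold more compounds than are shown below. What is called first, only, known or untested is meant among the compounds shown, and "the series" means these compounds.

Measured compounds in a functional assay on SW480 cells (Homo sapiens) for antiproliferative activity; a higher number here means a weaker inhibitor, a lower number a stronger inhibitor:
compound 1 `COc1cccc(/C=C2/C(C)=C(CC(=O)O)c3cc(F)ccc32)c1` gives 360000 nM
compound 2 `COc1ccccc1/C=C1/C(C)=C(CC(=O)O)c2cc(F)ccc21` gives 850000 nM
compound 3 `CC1=C(CC(=O)O)c2cc(F)ccc2/C1=C\c1ccc(C)o1` gives 380000 nM; 80000 nM (2 entries)

In this assay compound 2 stands highest of the two single numbers. The nearest is compound 1, and the step of a 2.4-fold higher number from compound 1 to compound 2 (0.37 log units; beyond the scatter) is modest. Compound 3 carries two entries that do not settle on one number.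

Compound 4 `CC1=C(CC(=O)O)c2cc(F)ccc2/C1=C\c1cccs1` differs from compound 2 in one place: thiophen-2-yl in place of 2-methoxyphenyl on a double-bonded chain carbon bound to a double-bonded ring carbon. Among the compounds with values here, the only measured step, a 2.4-fold higher number from compound 1 to compound 2 (0.37 log units; beyond the scatter), shifts a methoxy group between two positions on a six-membered aromatic ring and says little about exchanging that ring for a five-membered heteroaryl. Compound 3 is the closest guide, since the several entries of compound 3 in this assay, 380000 nM; 80000 nM (2 entries) shows a five-membered heteroaryl at the same place giving numbers lower than that of compound 2 in both entries, though the two entries are far apart.

Compound 4 is therefore expected to give 300000 nM in this assay, with a range of 80000 nM to 1000000 nM. The expected step of a 2.8-fold lower number from compound 2 to compound 4 (0.45 log units; beyond the scatter) is a lowering, modest in size and uncertain given the spread seen for compound 3.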

Compound 4, half-maximal inhibitory concentration: 320000 nM
Compound 4: middle estimate off by 1.1-fold (0.03 log units), on the low side; the range from low to high includes it.
By their numbers in this assay, from the lowest: compounds 4 and 1 (each within the scatter of the next); then compound 2.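

In this assay, thiophen-2-yl in place of 2-methoxyphenyl gives a 2.7-fold lower number from compound 2 to compound 4 (0.42 log units; beyond the scatter), so a five-membered aromatic ring with one hetero atom is accepted at this place without any loss against compound 2. The same exchange starting from 3-methoxyphenyl gives a 1.1-fold lower number from compound 1 to compound 4 (0.05 log units; within the scatter), so the lowering holds only against 2-methoxyphenyl, and thiophen-2-yl does no more than match 3-methoxyphenyl. A five-membered heteroaryl at this place now has one single number, which compound 3 could not supply: the several entries of compound 3 in this assay, 380000 nM; 80000 nM (2 entries)

As far as these compounds go, how an unsubstituted phenyl, a pyridin-3-yl or an aryl ring carrying an amine would behave at this place remains open. Also open, from the compounds shown here alone, is whether an amide in place of the carboxylic acid would move these numbers.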